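The compounds below may be only part of what the source reports. "The series", "measured", "known", "first", "only" and "open" are said of these compounds alone.

Compound 1 `COc1nc(Cl)nc2c1ncn2[C@@H]1O[C@H](CO)[C@@H](O)[C@@]1(C)O` was measured in an ADME assay on PBMC cells (Homo sapiens) for cytotoxicity, read by trypan blue exclusion, with a stated time of 6 days (a lower number here means that less compound is tolerated, a higher number that more compound is tolerated), where compound 1 gives > 100000 nM, a limit of the assay rather than a number.
Compound 2 `C[C@@]1(O)[C@H](O)[C@@H](CO)O[C@H]1n1cnc2c(N)nc(N=[N+]=[N-])nc21`: in this assay compound 2 gives > 100000 nM, again a limit of the assay.
Compound 3 `COc1nc(ONC(=O)OCc2ccccc2)nc2c1ncn2[C@@H]1O[C@H](CO)[C@@H](O)[C@@]1(C)O`: in this assay compound 3 gives > 100000 nM, once more a limit of the assay.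

Compound 3 therefore stands nowhere in particular on these numbers: its result is a limit, and the two other results shown are limits as well. Among the measured compounds shown here, all three values sit at the limit of > 100000 nM in this assay, at which 3 of the 3 values shown sit, so no ordering among the three measured compounds can be read out, and no step between measured compounds that differ in one place exists to lean on.

Compound 4 `COc1nc(O)nc2c1ncn2[C@@H]1O[C@H](CO)[C@@H](O)[C@@]1(C)O` is the next compound to be measured in this assay. It differs from compound 3 in a single respect: hydrogen in place of (benzyloxycarbonyl)amino on an oxygen on an aromatic ring. With every measured compound, including compound 3, at the same limit, the account expects no step beyond the usual scatter for this change, in either direction. The expected step is a number no higher from compound 3 to compound 4 (the limit leaves the size open). Compound 4 is accordingly estimated at 100000 nM, with a range from 40000 nM to 300000 nM, and most likely the assay will again report only a limit.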

Compound 4, half-maximal cytotoxic concentration: > 100000 nM
Compound 4 gave a limit, no number (the forecaster's own chance of this, stated with the estimate: 85%); the middle value sits exactly at the limit.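

Compound 4 gives > 100000 nM in this assay, which is a limit of the assay. Among the compounds shown here, no step from compound 3 or compound 1 to compound 4 can be read, because all the results are limits: the limit of > 100000 nM in this assay, at which 4 of the 4 values shown sit. The compounds shown leave open whether exchanging (benzyloxycarbonyl)amino for hydrogen, or chloro for hydroxy, changes the tolerated concentration at all.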